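Phenyl in place of morpholine on a benzyl amide

This account rests on a few compounds, and the source may have more. Where it says the series, first, only, none or still open, it means among the compounds named here.

Compound 1 `COC(=O)CC1c2ccccc2N=C(N2CCOCC2)N1c1ccccc1` gives 14% in a functional assay on cells (Oocyte) for inhibition of Voltage-dependent T-type calcium channel subunit alpha-1H (Homo sapiens), tested at 100 uM; on this read-out lower numbers stand for less inhibition and higher numbers for more inhibition at the one concentration tested (going by the name of the read-out). Compound 2 `COC(=O)CC1c2ccccc2N=C(c2ccccc2)N1c1ccccc1` gives 51.5% in this assay; the change is phenyl in place of morpholin-4-yl on a carbon with a double bond to nitrogen, a step of a number 37.5 percentage points higher from compound 1 to compound 2 (beyond the scatter). Compound 3 `O=C(CC1c2ccccc2N=C(N2CCOCC2)N1c1ccccc1)NCc1ccccc1` gives 63.8% in this assay and differs from compound 1 by benzylamino in place of methoxy on a carbonyl carbon, a step of a number 49.8 percentage points higher from compound 1 to compound 3 (beyond the scatter). Compound 4 `O=C(CC1c2ccccc2N=C(c2ccccc2)N1c1ccccc1)NCc1ccccc1` has not yet been measured. It differs from compound 3 by phenyl in place of morpholin-4-yl on a carbon with a double bond to nitrogen, the same kind of change as from compound 1 to compound 2, though here the ring atom two ring bonds away bears a (benzylcarbamoyl)methyl group rather than a (methoxycarbonyl)methyl group. Compound 4 is expected to reach about 82% in this assay, an estimated step of a number 18.2 percentage points higher from compound 3 to compound 4 (beyond the scatter). This expectation rests on the earlier step being a number 37.5 percentage points higher from compound 1 to compound 2 (beyond the scatter) and on compound 3 already giving 63.8%, which leaves less room upward.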

Compound 4, a percentage reported as inhibition, at one concentration (the size of the read-out at that concentration, not a potency): 14.8%
Compound 4: the middle estimate sits 67.2 percentage points above what was measured, and the stated range ends above it.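

In this assay, phenyl in place of morpholin-4-yl does not carry over from the core of compound 1 to the core of compound 3, giving a step of a number 49 percentage points lower from compound 3 to compound 4 (beyond the scatter), which runs against the earlier one: the same change on two cores in this assay, a number 37.5 percentage points higher (beyond the scatter) from compound 1 to compound 2 and a number 49 percentage points lower (beyond the scatter) from compound 3 to compound 4, 86.5 percentage points apart, beyond the scatter of two such steps The change of methoxy to benzylamino turns round in the same way, giving a step of a number 36.7 percentage points lower from compound 2 to compound 4 (beyond the scatter): the same change on two cores in this assay, a number 49.8 percentage points higher (beyond the scatter) from compound 1 to compound 3 and a number 36.7 percentage points lower (beyond the scatter) from compound 2 to compound 4, 86.5 percentage points apart, beyond the scatter of two such steps Across these four compounds, the effect of each change depends on the group at the other place, but they do not show why this happens or whether it extends beyond these groups.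

Going by these compounds, it remains open whether the reversal is specific to phenyl and benzylamino. Piperidin-1-yl in place of morpholin-4-yl, or methylamino in place of benzylamino, could help settle this.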